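Chain variants in growth inhibition: compound 3 to compound 4

A few compounds are considered here, and "the series" means these few. Any claim that something is new, unique, unknown or untested is made for them only; others in the source may bear on it.

- compound 1 `OC[C@@H]1O[C@H](COCc2ccccc2)[C@@H](OCc2ccccc2)[C@H](OCc2ccccc2)[C@H]1O`: 25800 nM
- compound 2 `OCC[C@@H]1O[C@H](COCc2ccccc2)[C@@H](OCc2ccccc2)[C@H](OCc2ccccc2)[C@H]1O`: 30200 nM
- compound 3 `OCCC[C@@H]1O[C@H](COCc2ccccc2)[C@@H](OCc2ccccc2)[C@H](OCc2ccccc2)[C@H]1O`: > 50000 nM

All values come from a functional assay on HeLa cells (Homo sapiens) for antiproliferative activity, read by sulforhodamine B assay; a lower number here means a stronger inhibitor of growth, a higher number a weaker inhibitor of growth. Compound 3 gives > 50000 nM, which is a limit of the assay and not a number.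

Compound 4 `O[C@@H]1[C@@H](OCc2ccccc2)[C@H](OCc2ccccc2)[C@@H](COCc2ccccc2)O[C@H]1CC1CC1` carries cyclopropyl in place of 2-hydroxyethyl on a saturated chain carbon bound to a saturated ring carbon.

The measured steps only vary the hydroxy-bearing chain: a 1.2-fold higher number from compound 1 to compound 2 (0.07 log units; within the scatter), an at least 1.9-fold higher number from compound 1 to compound 3 (0.28 log units; that floor lies within the scatter) and an at least 1.6-fold higher number from compound 2 to compound 3 (0.21 log units; that floor lies within the scatter). None of them removes the hydroxy or adds a ring, so they bear on this change only loosely. No step beyond the scatter is expected, and the estimated step is an at least 1.4-fold lower number from compound 3 to compound 4 (0.15 log units; that floor lies within the scatter).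

For compound 4 the estimate is 35000 nM, with an expected range of 14000 nM to 60000 nM.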

Compound 4, concentration for 50% growth inhibition: > 50000 nM
Compound 4: a limit, no number; the forecaster's own chance of this, stated with the estimate: 40%; middle value at least 1.4-fold (0.15 log units) from the limit.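

Compound 4 gives > 50000 nM, a limit of the assay and not a number, so cyclopropyl on this saturated chain carbon, with no hydroxy on the chain, gives no readable value. Against the shorter hydroxy chains, the result reads as an at least 1.6-fold higher number from compound 2 to compound 4 (0.21 log units; that floor lies within the scatter) and as an at least 1.9-fold higher number from compound 1 to compound 4 (0.28 log units; that floor lies within the scatter). The step from compound 3 cannot be read, because both compounds sit at the limit: the limit of > 50000 nM in this assay, at which 2 of the 4 values shown sit.

As far as these compounds go, the change removes the hydroxy and adds a ring at once, so the share of each stays open. From the compounds shown here alone, how an amine or a carboxylic acid at this place would read also stays open.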